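The source may hold more compounds than are shown below. What is called first, only, known or untested is meant among the compounds shown, and "the series" means these compounds.

Measured compounds:
compound 1, `O=C(Nc1ccc(C(F)(F)F)cc1)c1cc(Br)ccc1O`, 1090 nM in a functional assay on NALM-6 cells (Homo sapiens) for cytotoxicity, read by luminescence and CellTiter-Glo, with a stated time of 3 days; a lower number here means a stronger inhibitor, a higher number a weaker inhibitor
compound 2, `O=C(Nc1ccccc1)c1cc(F)ccc1O`, "not determined" (no result reported) in this assay

Compound 2 stands without a number in this assay: the assay was run in the series, but no result is reported for it, so there is no value to place beside compound 1. Compound 1 gives 1090 nM in this assay and is the only measured point.

Compound 3, `O=C(Nc1ccc(C(F)(F)F)cc1)c1cc(F)ccc1O`, is the next member. It differs from compound 2 in one place: trifluoromethyl in place of hydrogen on an aromatic carbon. The shared core of the two is otherwise the same. Going by the values given here, with compound 2 unmeasured, no step in this assay can be computed for this change, and its direction cannot be read from the two compounds themselves.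

Compound 3 carries the same trifluoromethyl-bearing aryl amide as compound 1, and compound 1 gives 1090 nM; the two differ only in the halogen on the phenol ring, for which no step is shown. Compound 3 is expected to land near compound 1 or weaker, at about 3000 nM, within 800 nM to 12000 nM.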

Compound 3, half-maximal inhibitory concentration: 2090 nM
Compound 3: middle estimate off by 1.4-fold (0.16 log units), on the high side; the range from low to high includes it.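

In this assay, fluoro in place of bromo on an aromatic carbon gives a 1.9-fold higher number from compound 1 to compound 3 (0.28 log units; within the scatter) and does not separate the two halogens on this pair. Going by these compounds alone, with the trifluoromethyl-bearing aryl amide held constant, this is the first comparison at the halogen position, and the exchange stays inside the usual scatter of repeated measurements, so bromo and fluoro count as equivalent here within the limits of this single pair. Nothing measured here speaks to why the two compounds read alike.

The step for trifluoromethyl in place of hydrogen cannot be read, with no result reported for compound 2, and what the trifluoromethyl group contributes in this assay remains unanswered. Also open, going by these compounds, is what a nitrile, an amine or a carboxylic acid would give in place of the halogen, and what a longer chain would give in place of trifluoromethyl on the same six-membered aromatic ring.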